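Sulfonyl for Carbonyl on the Anilide Nitrogen

This account rests on a few compounds, and the source may have more. Where it says the series, first, only, none or still open, it means among the compounds named here.

Measured in a functional assay on HCT-116 cells (Homo sapiens) for antiproliferative activity, read by MTT assay, with a stated time of 48 h; a lower number here means a stronger inhibitor, a higher number a weaker inhibitor:
- compound 1, `O=C(/C=C/c1cccc(NC(=O)c2ccccc2Cl)c1)c1nc2ccccc2[nH]1`, 1280 nM
- compound 2, `O=C(/C=C/c1cccc(NC(=O)c2ccccc2Br)c1)c1nc2ccccc2[nH]1`, 1680 nM
- compound 3, `COc1ccc(C(=O)Nc2cccc(/C=C/C(=O)c3nc4ccccc4[nH]3)c2)cc1`, 4880 nM

Compound 3 has the highest number of the three in this assay. The steps to it are a 3.8-fold higher number from compound 1 to compound 3 (0.58 log units; beyond the scatter) and a 2.9-fold higher number from compound 2 to compound 3 (0.46 log units; beyond the scatter), both beyond the scatter, whereas a 1.3-fold higher number from compound 1 to compound 2 (0.12 log units; within the scatter) stays within it. Compound 4, `Cc1cccc(S(=O)(=O)Nc2cccc(/C=C/C(=O)c3nc4ccccc4[nH]3)c2)c1`, differs from compound 3 by (3-methylphenyl)sulfonyl in place of (4-methoxyphenyl)carbonyl on a nitrogen on an aromatic ring. Going by the values given here, no measured step exchanges the carbonyl for a sulfonyl, so the only guidance is that replacing the aryl group on the carbonyl moved the numbers only modestly, as in a 3.8-fold higher number from compound 1 to compound 3 (0.58 log units; beyond the scatter). The direction of a change at the linking group itself is therefore open. Compound 4 is expected to land near compound 3, with a 1.4-fold lower number from compound 3 to compound 4 (0.14 log units; within the scatter) as the estimated step, and a wide range to reflect the lack of a comparable measured step. The estimate for compound 4 in this assay is 3500 nM, between 1200 nM and 10000 nM.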

Compound 4, half-maximal inhibitory concentration: 597 nM
The estimate for compound 4 lay 5.9-fold (0.77 log units) above the measured number, and the stated range ends above it.
By their numbers in this assay, from the lowest: compound 4; then compounds 1 and 2 (each within the scatter of the next); then compound 3.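

In this assay, going by these compounds alone, the substituent on this nitrogen can carry a sulfonyl link as well as a carbonyl link, and the change to (3-methylphenyl)sulfonyl gives an 8.2-fold lower number from compound 3 to compound 4 (0.91 log units; beyond the scatter), a larger step than any among the earlier compounds. The same group also goes beyond the scatter against the two ortho-free-named partners. 

Correction of the above, final text:

In this assay, within the data shown here, this nitrogen accepts a sulfonyl link as well as a carbonyl link, and (3-methylphenyl)sulfonyl in place of (4-methoxyphenyl)carbonyl gives an 8.2-fold lower number from compound 3 to compound 4 (0.91 log units; beyond the scatter), a larger step than any among the earlier compounds. The same group also improves on the two halogen-bearing aryl carbonyl groups, with a 2.8-fold lower number from compound 2 to compound 4 (0.45 log units; beyond the scatter) and a 2.1-fold lower number from compound 1 to compound 4 (0.33 log units; beyond the scatter), which leaves compound 4 with the lowest number of the four. Nothing available explains why the number falls at this position.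

Because the link and the aryl group change together in every one of these steps, the compounds shown cannot separate the effect of the sulfonyl from that of the 3-methylphenyl group. On these data alone, it also remains open how (4-methoxyphenyl)sulfonyl, (3-methylphenyl)carbonyl or a simple methylsulfonyl group would behave on this nitrogen.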